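The source may report more compounds than this note shows. Statements on the series, on what has been measured and on what is new or still open speak of the compounds shown alone.

Working notes on the series. In an in vivo ADME assay on the whole organism (plasma) for pharmacokinetics, with Rattus norvegicus as the target, at a dose of 50 mg/kg by the oral route (on this read-out higher numbers stand for higher exposure at the dose given and lower numbers for lower exposure), compound 1 `Cc1cc(C)c(NC(=O)c2sccc2S(=O)(=O)Nc2onc(C)c2Cl)c(C)c1CO` gives 5110 nM and compound 2 `COc1c(C)cc(C)c(NC(=O)c2sccc2S(=O)(=O)Nc2onc(C)c2Cl)c1C` gives 8510 nM. These two values lie within the scatter of each other, so compound 2 stands level with compound 1 on the numbers available.

Compound 3 `Cc1cc(C)c(OC2CC2)c(C)c1NC(=O)c1sccc1S(=O)(=O)Nc1onc(C)c1Cl` carries one change relative to compound 2: cyclopropyl in place of methyl on an oxygen on an aromatic ring. In words, this is cyclopropyl in place of methyl on an oxygen on an aromatic ring.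

Going by the values given here, only one measured step bears on this change, and only loosely: a 1.7-fold higher number from compound 1 to compound 2 (0.22 log units; within the scatter), for methoxy in place of hydroxymethyl on an aromatic carbon. Among the compounds with values here, that step stays within the scatter, and no measured compound carries cyclopropyloxy, so the data give no direction for the change. No step beyond the scatter is therefore expected in this assay, and the expectation stays anchored on compound 2 at 8510 nM, with wide margins.

The expected change is a 1.2-fold lower number from compound 2 to compound 3 (0.08 log units; within the scatter).

For compound 3 the estimated value is 7000 nM, with an expected range from 2500 nM to 18000 nM.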

Compound 3, maximal plasma concentration: 12300 nM
For compound 3 the middle estimate is 1.8-fold (0.24 log units) below the measured one, and the stated range covers the measured number.
By their numbers in this assay, from the lowest: compounds 1, 2 and 3 (each within the scatter of the next, the first and the last beyond it).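

In this assay cyclopropyl on the oxygen in place of methyl gives a 1.4-fold higher number from compound 2 to compound 3 (0.16 log units; within the scatter), so cyclopropyloxy stands level with methoxy and the position takes a three-membered carbon ring with no shift beyond the scatter. Set against hydroxymethyl, the same group gives a 2.4-fold higher number from compound 1 to compound 3 (0.38 log units; beyond the scatter), a modest step and the only one at this position beyond the scatter, and it appears only between the two ends of the series, as compound 2 lies within the scatter of both compound 1 and compound 3. No evidence at hand accounts for either step.

As far as these compounds go, it remains open whether the difference from hydroxymethyl belongs to an oxygen directly on the aromatic carbon or to cyclopropyl itself, as methoxy and cyclopropyloxy cannot be separated on these numbers. Also open, from the compounds shown here alone, is how an amine, a carboxylic acid or a longer chain such as butoxy in the same place would read in this assay, and whether any of them would depart beyond the scatter from compound 2 or compound 3 .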